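The source may hold more compounds than are shown below. What is called first, only, known or untested is meant among the compounds shown, and "the series" means these compounds.

Measured compounds:
compound 1 `CC(C(=O)N1CCN(c2ccccc2F)CC1)N1C(=O)CCC1=O`, 100%
compound 2 `CCC(C(=O)N1CCN(c2ccc(F)cc2)CC1)N1C(=O)CCC1=O`, 0%
compound 3 `CC(C(=O)N1CCN(c2ccc(F)cc2)CC1)N1C(=O)CCC1=O`, 100%

In a functional assay on the whole organism (strain Swiss) with Mus musculus as the target, in the maximal electroshock model, with a stated time of 0.25 h, at a dose of 300 mg/kg by the intraperitoneal route (a higher number here means a stronger effect of the compound at the dose given, a lower number a weaker effect), compound 3 gives 100% and compound 1 gives 100%; they differ by 2-fluorophenyl in place of 4-fluorophenyl on an amine nitrogen in a ring, and that step is no change at the digits printed from compound 3 to compound 1 (within the scatter). Compound 2 differs from compound 3 in the core: methyl in place of hydrogen on a saturated chain carbon, two bonds along the chain from an amide-type nitrogen in a ring and a carbonyl carbon. In this assay compound 2 gives 0%, so the step is a number 100 percentage points higher from compound 2 to compound 3 (beyond the scatter). Compound 4 `CCC(C(=O)N1CCN(c2ccccc2F)CC1)N1C(=O)CCC1=O` has not been measured yet; it differs from compound 2 by 2-fluorophenyl in place of 4-fluorophenyl on an amine nitrogen in a ring, at the same place as in the measured pair. Because no change at the digits printed from compound 3 to compound 1 (within the scatter) stayed within the scatter, the corresponding step is expected to be a number 10 percentage points higher from compound 2 to compound 4 (within the scatter), though a single measured pair is a thin basis. Compound 4 is therefore estimated at 10%, likely between 0% and 60%.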

Compound 4, a percentage reported as activity, at one dose (the size of the read-out at that dose, not a potency): 100%
For compound 4 the middle estimate is 90 percentage points below the measured one; measured number outside the range, above it.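

In this assay, putting 2-fluorophenyl in place of 4-fluorophenyl gives a number 100 percentage points higher from compound 2 to compound 4 (beyond the scatter), so the result of this change depends on the core that carries it: the same change on two cores in this assay, no change at the digits printed (within the scatter) from compound 3 to compound 1 and a number 100 percentage points higher (beyond the scatter) from compound 2 to compound 4, 100 percentage points apart, beyond the scatter of two such steps Adding the methyl on the saturated chain carbon also depends on the other part of the molecule, with no change at the digits printed from compound 1 to compound 4 (within the scatter): the same change on two cores in this assay, a number 100 percentage points higher (beyond the scatter) from compound 2 to compound 3 and no change at the digits printed (within the scatter) from compound 4 to compound 1, 100 percentage points apart, beyond the scatter of two such steps This shows that the two changes cannot be treated as separate, additive steps in this small set, but it does not show why, and the whole pattern rests on compound 2 standing apart from the other three compounds.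

Going by these compounds, it remains open whether an ethyl group in place of the methyl would behave as the methyl does. On these data alone, it also remains open whether a chlorophenyl group in place of either fluorophenyl would follow the same pattern.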